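This account rests on a few compounds, and the source may have more. Where it says the series, first, only, none or still open, it means among the compounds named here.

In a functional assay on U-251 cells (Homo sapiens) for inhibition, read by sulforhodamine B assay, with a stated time of 48 h (a higher number here means that more compound is tolerated, a lower number that less compound is tolerated), compound 2 `COc1cc(-c2nn(-c3cccc(NC(=O)c4cccc(C(F)(F)F)c4)c3)cc2-c2ccncc2)ccc1Cl` gives only a limit, > 50000 nM. Compound 1 `COc1cc(-c2nn(-c3cccc(NC(=O)c4ccc(Cl)c(C(F)(F)F)c4)c3)cc2-c2ccncc2)ccc1Cl` also gives only a limit in this assay, > 32500 nM. The step from compound 1 to compound 2 is therefore unreadable, a step that the two limits leave unreadable from compound 1 to compound 2, because both values sit at limits the limit of > 32500 nM in this assay, at which 1 of the 3 values shown sits, and (the limit of > 50000 nM in this assay, at which 1 of the 3 values shown sits). Compound 3 `O=C(Nc1cccc(-n2cc(-c3ccncc3)c(-c3ccc(Cl)c(O)c3)n2)c1)Nc1cc(C(F)(F)F)cc(C(F)(F)F)c1` differs from compound 2 in several places; in this assay compound 3 gives 2800 nM.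

Compound 4 `COc1cc(-c2nn(-c3cccc(NC(=O)c4ccccc4)c3)cc2-c2ccncc2)ccc1Cl` differs from compound 2 in one place: hydrogen in place of trifluoromethyl on an aromatic carbon. Among the compounds with values here, no measured step bears directly on this change, and the only step between related compounds cannot be read. With compound 2 at a limit, compound 4 is expected to sit near 50000 nM, within 20000 nM to 100000 nM. The expected step from compound 2 to compound 4 is a number no higher from compound 2 to compound 4 (the limit leaves the size open).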

Compound 4, concentration lethal to 50% of the cells: > 100000 nM
Compound 4 was reported as a limit; the forecaster's own chance of this, stated with the estimate: 70%; middle value at least 2.0-fold (0.30 log units) from the limit.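

Compound 2 and compound 4 both give only limits, as does compound 1, so neither new step to compound 4 can be read. The compounds shown leave open whether hydrogen in place of trifluoromethyl changes anything in this assay.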